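Phenoxy to 3-methyl-1,2,4-oxadiazol-5-yl on a shared core

The source may report more compounds than this note shows. Statements on the series, on what has been measured and on what is new or still open speak of the compounds shown alone.

Measured compounds:
compound 1 `CN(C)[C@H]1C[C@H](c2c[nH]c3ccc(CN4C(=O)CNC4=O)cc32)C1`: 2450 nM
compound 2 `CN(C)[C@H]1C[C@H](c2c[nH]c3ccc(Oc4ccccc4)cc32)C1`: 64.6 nM

Going by the values given here, in an assay on CHO-K1 cells for binding affinity to 5-hydroxytryptamine receptor 1D (Homo sapiens) (on this read-out higher numbers stand for weaker inhibition and lower numbers for stronger inhibition), compound 2 gives 64.6 nM, the lower of the two numbers measured so far, while compound 1 gives 2450 nM. The two are separated by a 38-fold lower number from compound 1 to compound 2 (1.58 log units; beyond the scatter), a change of the group on the aromatic carbon of the shared core.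

Compound 3 `Cc1noc(-c2ccc3[nH]cc([C@H]4C[C@H](N(C)C)C4)c3c2)n1` carries the same core and basic amine and differs from compound 2 only at that carbon: 3-methyl-1,2,4-oxadiazol-5-yl in place of phenoxy on an aromatic carbon. Among the compounds with values here, the single measured step, the one from compound 1 to compound 2, concerns the same position and was large, but neither of its groups is the one entering here. One six-membered aromatic ring of carbon only leaves and one five-membered aromatic ring with three hetero atoms and three acceptors enters, so the comparison is indirect. Compound 3 is expected to land between the two measured values, closer to compound 2, with a moderate rise in this assay of about a 3.9-fold higher number from compound 2 to compound 3 (0.59 log units; beyond the scatter). The estimate for compound 3 is 250 nM, within 60 nM to 1000 nM.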

Compound 3, half-maximal inhibitory concentration: 562 nM
Compound 3: middle estimate off by 2.2-fold (0.35 log units), on the low side, and the stated range covers the measured number.
By their numbers in this assay, from the lowest: compound 2; then compound 3; then compound 1.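

In this assay, this aromatic carbon now carries three different groups, and the numbers fall into three separate levels rather than two. The 3-methyl-1,2,4-oxadiazol-5-yl group gives an 8.7-fold higher number from compound 2 to compound 3 (0.94 log units; beyond the scatter), yet it keeps a clear lead over the (2,5-dioxoimidazolidin-1-yl)methyl group, with a 4.4-fold lower number from compound 1 to compound 3 (0.64 log units; beyond the scatter). The step from phenoxy also shows that the number can move beyond the scatter when neither group has a hydrogen-bond donor or a net charge, while hydrogen-bond acceptors rise from 1 to 3 and the six-membered aromatic ring of carbon only gives way to a five-membered aromatic ring with 3 hetero atoms; no other measurement bears on the reason for this rise.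

These changes all arrive together in one step, so the compounds shown cannot assign the rise to ring size, hetero atoms, acceptor count or the loss of the oxygen that links the phenyl ring in phenoxy. A pyridyloxy group or a plain phenyl ring on this carbon would help separate those changes, and an ethyl or longer chain in place of the methyl would test whether the ring's substituent matters.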